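Swapping the fluorinated ring of compound 2 for a new ring

The source may hold more compounds than are shown below. What is called first, only, known or untested is meant among the compounds shown, and "the series" means these compounds.

Measured compounds:
compound 1 `NC1(CCn2ncc(=O)[nH]c2=O)OC(=O)C(OCc2ccccc2)=C1OCc1ccccc1`: > 100000 nM
compound 2 `NC1(CCn2cc(F)c(=O)[nH]c2=O)OC(=O)C(OCc2ccccc2)=C1OCc1ccccc1`: 36200 nM

Of the compounds shown here, two that share a core have been tested in an ADME assay on WI-38 cells (Homo sapiens) for inhibition, read by MTT assay, with a stated time of 72 h; a lower number here means a stronger inhibitor, a higher number a weaker inhibitor. Compound 1 gives only a limit, > 100000 nM, a bound of the assay rather than a number. Among the compounds with values here, compound 2 gives 36200 nM, the only actual number among the results, so compound 2 is the only compound with a measured inhibition here. The step between them, an at least 2.7-fold lower number from compound 1 to compound 2 (0.44 log units; beyond the scatter), is tied to the bound the limit of > 100000 nM in this assay, at which 1 of the 2 values shown sits, and so its true size is not known.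

Compound 3 `Nc1ccn(CCC2(N)OC(=O)C(OCc3ccccc3)=C2OCc2ccccc2)c(=O)n1` is not yet measured. It differs from compound 2 as follows: a group of 8 heavy atoms (4 carbon, 3 nitrogen, 1 oxygen; one six-membered aromatic ring with 2 hetero atoms) in place of a group of 9 heavy atoms (4 carbon, 2 nitrogen, 2 oxygen, 1 fluorine; one six-membered aromatic ring with 2 hetero atoms), on a saturated chain carbon, two bonds along the chain from a saturated ring carbon. Within the data shown here, only one measured step exists and it touches the same place, but it involves a different pair of rings and rests on a limit, so it is a weak guide. Compound 3 is expected to lose the gain seen in compound 2 and to sit near the bound of this assay, giving an estimated 100000 nM with a range of 30000 nM to 300000 nM. The expected step is a 2.8-fold higher number from compound 2 to compound 3 (0.44 log units; beyond the scatter).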

Compound 3, half-maximal inhibitory concentration: 88900 nM
Compound 3: middle estimate off by 1.1-fold (0.05 log units), on the high side; the range from low to high includes it.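

In this assay the ring swap on the saturated chain carbon gives a 2.5-fold higher number from compound 2 to compound 3 (0.39 log units; beyond the scatter) and this modest step is read between two actual numbers, whereas the earlier step at this place rested on a limit. The change takes out a group of 9 heavy atoms that includes fluorine and puts in a group of 8 heavy atoms without it, so this position is shown to respond to a ring swap even when both rings are six-membered aromatic rings with 2 hetero atoms. Compound 1 gives only a limit and not a number. The other new step of an at least 1.1-fold lower number from compound 1 to compound 3 (0.05 log units; that floor lies within the scatter) is therefore only a floor, and its true size cannot be read, because it is tied to a bound of the assay: the limit of > 100000 nM in this assay, at which 1 of the 3 values shown sits.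

The compounds shown leave open whether the fluorine alone lies behind the step, as the entering group differs from the leaving one in more than that atom. They also leave open how the same ring would read with a chlorine atom or a methyl group where the fluorine stands, or with a longer chain joining it to the shared core.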